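A larger amide substituent on a shared core

This account rests on a few compounds, and the source may have more. Where it says the series, first, only, none or still open, it means among the compounds named here.

Measured compounds:
compound 1, `CNC(=O)c1ccncc1Nc1cc(-c2ccc3ccn(C)c3c2)c2nccnc2c1`, 83 nM
compound 2, `Cn1cc(NC(=O)c2ccncc2Nc2cc(-c3ccc4ccn(C)c4c3)c3nccnc3c2)cn1`, 33 nM
compound 3, `Cn1ccc2ccc(-c3cc(Nc4cnccc4C(=O)NCC4COCCN4)cc4nccnc34)cc21`, 33 nM

In an assay for inhibition of 6-phosphofructo-2-kinase/fructose-2,6-bisphosphatase 3 (Homo sapiens), read by ADP-Glo, with a stated time of 2 h (on this read-out higher numbers stand for weaker inhibition and lower numbers for stronger inhibition), compound 1 gives 83 nM, the highest number among the three measured compounds. The two known steps from it both lower the number: a 2.5-fold lower number from compound 1 to compound 2 (0.40 log units; beyond the scatter), and a 2.5-fold lower number from compound 1 to compound 3 (0.40 log units; beyond the scatter). Between the two larger amide substituents there is no separation, as no change at the digits printed from compound 2 to compound 3 (within the scatter) shows.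

Compound 4, `CN1CCC(CNC(=O)c2ccncc2Nc2cc(-c3ccc4ccn(C)c4c3)c3nccnc3c2)C1`, has not been measured. It differs from compound 1 by 1-methylpyrrolidin-3-yl in place of hydrogen on a saturated chain carbon bound to an amide-type nitrogen. Among the compounds with values here, this change is most like the one from compound 1 to compound 3, which also placed a saturated ring at the same place and gave a modest lowering; compound 2 points the same way. Compound 4 is therefore expected to show a modest lowering in this assay, a 2.1-fold lower number from compound 1 to compound 4 (0.32 log units; beyond the scatter), and the estimate for compound 4 is 40 nM, with a range from 20 nM to 80 nM.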

Compound 4, half-maximal inhibitory concentration: 74 nM
Compound 4: the middle estimate sits 1.9-fold (0.27 log units) below what was measured, within the range that was stated.
By their numbers in this assay, from the lowest: compounds 2 and 3 (each within the scatter of the next); then compounds 4 and 1 (each within the scatter of the next).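

In this assay, a larger saturated ring group at this saturated chain carbon does not by itself bring the lowering seen with morpholin-3-yl: with 1-methylpyrrolidin-3-yl in place of hydrogen, the result is within the scatter (a 1.1-fold lower number from compound 1 to compound 4 (0.05 log units; within the scatter)). The identity of the ring matters at this place, as the two ring groups are separated beyond the scatter (a 2.2-fold higher number from compound 3 to compound 4 (0.35 log units; beyond the scatter)). The 1-methyl-1H-pyrazol-4-yl amide also stands apart from compound 4 (a 2.2-fold higher number from compound 2 to compound 4 (0.35 log units; beyond the scatter)), and no measurement given here accounts for these differences.

The compounds shown leave open whether a pyrrolidin-3-yl without the methyl group on its nitrogen, or a piperidin-3-yl ring, would follow compound 3 or compound 4. They also leave open how an open-chain dimethylamino group on a longer chain would compare at this carbon.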